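This account rests on a few compounds, and the source may have more. Where it says the series, first, only, none or still open, it means among the compounds named here.

Measured in a functional assay on the whole organism for inhibition, with Rattus norvegicus as the target; on this read-out higher numbers stand for an effect only at larger amounts of compound and lower numbers for an effect already at smaller amounts:
- compound 1 `CCCCc1nc(SC)c(C(=O)C[S+](C)[O-])n1Cc1ccc(-c2ccccc2S(=O)(=O)NC(=O)NCc2ccccc2)cc1`: 0.7 mg/kg
- compound 2 `CCCc1nc(SC)c(C(=O)C[S+]([O-])c2ccc(C)cc2)n1Cc1ccc(-c2ccccc2S(=O)(=O)NC(=O)NCc2ccccc2)cc1`: 1.5 mg/kg; 1.5 mg/kg (2 entries)

Compound 1 has one number in this assay, with one further entry that gives no single number. Within the data shown here, compound 2 is the only other measured compound, and it differs from compound 1 in more than one place, so the series has no single-change step to calibrate against.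

The compound next in line is compound 3 `CCCCc1nc(SC)c(C(=O)CS(=O)(=O)c2ccc(F)cc2)n1Cc1ccc(-c2ccccc2S(=O)(=O)NC(=O)NCc2ccccc2)cc1`. Compared with compound 1, it carries a group of 10 heavy atoms (6 carbon, 2 oxygen, 1 fluorine, 1 sulfur; one six-membered aromatic ring of carbon only) in place of a group of 3 heavy atoms (1 carbon, 1 oxygen, 1 sulfur; no ring), on a saturated chain carbon bound to a carbonyl carbon. The rest of the structure is unchanged. The nearest guide is compound 2 at 1.5 mg/kg; 1.5 mg/kg (2 entries), whose group on the same saturated chain carbon also holds a six-membered aromatic ring of carbon only. That is one indirect comparison, so the expectation is weak. A modest move toward larger doses is expected, though a result within the usual scatter would not be surprising. The estimated size is a 2.1-fold higher number from compound 1 to compound 3 (0.33 log units; beyond the scatter). For compound 3 the expected value is 1.5 mg/kg, with an estimated range of 0.5 mg/kg to 4.5 mg/kg.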

Compound 3, dose for 50% inhibition: > 3 mg/kg
Compound 3: only a limit was reported; the forecaster's own chance of this, stated with the estimate: 5%; middle value at least 2.0-fold (0.30 log units) away from the limit.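

Compound 3 is reported in this assay only as a limit, > 3 mg/kg, and not as a number. Among these compounds, replacing the small sulfur-bearing group of compound 1 with (4-fluorophenyl)sulfonyl, on a saturated chain carbon bound to a carbonyl carbon, gives an at least 4.2-fold higher number from compound 1 to compound 3 (0.63 log units; beyond the scatter); this is the only single-change step, and it shows that the dose needed in this assay responds to the group at this position. The step sets only a minimum for the size of the change, and its full size stays unknown, as it rests on a limit: the limit of > 3 mg/kg in this assay, at which 1 of the 3 values shown sits.

The exchange brings in the aromatic ring and the sulfonyl group together, so the compounds shown cannot separate the contribution of one from the other. As far as these compounds go, a methylsulfonyl group at this place would test the sulfonyl group without the ring, a (4-fluorophenyl)sulfinyl group would test the ring without it, and whether an unsubstituted phenylsulfonyl group would differ from the 4-fluorophenyl version also remains open.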